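Replacing a cyclohexyl with a tolyl group at the amide branch

The source may report more compounds than this note shows. Statements on the series, on what has been measured and on what is new or still open speak of the compounds shown alone.

Of the compounds shown here, three of a shared core have been measured in an assay on CHO cells for antagonist activity at transient receptor potential cation channel subfamily V member 1 (Homo sapiens), read by FLIPR; a higher number here means a weaker inhibitor, a lower number a stronger inhibitor. Compound 1 `CC1CCN(c2nc(C(F)(F)F)ccc2CNC(=O)C(c2ccc(NS(C)(=O)=O)c(F)c2)C2CCCCC2)CC1` gives 31.1 nM. Compound 2 `CC1CCN(c2nc(C(F)(F)F)ccc2CNC(=O)C(c2ccc(F)cc2)c2ccc(NS(C)(=O)=O)c(F)c2)CC1` gives 3.4 nM, and compound 3 `CS(=O)(=O)Nc1ccc(C(C(=O)NCc2ccc(C(F)(F)F)nc2SC2CCCCC2)c2ccc(F)cc2)cc1F` gives 37.6 nM. Among these, compound 1 gives the second highest number, within the scatter of compound 3 and clearly apart from compound 2.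

Two single changes have been followed. a 9.1-fold lower number from compound 1 to compound 2 (0.96 log units; beyond the scatter) shows that swapping the saturated ring for an aromatic one at the carbon between the aryl and the carbonyl helps markedly. an 11-fold higher number from compound 2 to compound 3 (1.04 log units; beyond the scatter) concerns a different position and does not touch the change studied here.

Compound 4 `Cc1cccc(C(C(=O)NCc2ccc(C(F)(F)F)nc2N2CCC(C)CC2)c2ccc(NS(C)(=O)=O)c(F)c2)c1` differs from compound 1 in one place: 3-methylphenyl in place of cyclohexyl on a saturated chain carbon bound to an aromatic carbon and a carbonyl carbon. This resembles the move from compound 1 to compound 2, where an aromatic ring replaced the cyclohexyl at the same place, though here the ring carries a methyl instead of a fluorine. Given the size of a 9.1-fold lower number from compound 1 to compound 2 (0.96 log units; beyond the scatter), a drop of similar order is expected in this assay, with some uncertainty because the substitution on the new ring is different. For compound 4 the expected step is a 5.2-fold lower number from compound 1 to compound 4 (0.71 log units; beyond the scatter). The estimate for compound 4 is therefore 6 nM, with a range from 2 nM to 20 nM.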

Compound 4, inhibition constant: 0.1 nM
Beside the measured number, compound 4's estimate is 60-fold (1.78 log units) above it; measured number below the stated range.
By their numbers in this assay, from the lowest: compound 4; then compound 2; then compounds 1 and 3 (each within the scatter of the next).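

In this assay, an aromatic ring at this carbon again beats cyclohexyl, and the gain is far larger than the earlier fluorinated example suggested: a 310-fold lower number from compound 1 to compound 4 (2.49 log units; beyond the scatter), against a 9.1-fold lower number from compound 1 to compound 2 (0.96 log units; beyond the scatter). The new result also shows that having an aromatic ring here is only part of the story, since exchanging one substituted ring for another gives a 34-fold lower number from compound 2 to compound 4 (1.53 log units; beyond the scatter), so this position responds strongly to what the ring carries or where it carries it. No measurement shown here explains why 3-methylphenyl outperforms 4-fluorophenyl at this carbon.

That last comparison changes both the substituent and its place on the ring, so the effect of the methyl cannot be separated from the effect of its location. Results for 4-methylphenyl, 3-fluorophenyl and unsubstituted phenyl at this carbon would help pull those effects apart, while a 3-aminophenyl or 3-ethylphenyl group would test how much change the position tolerates at the site occupied by the methyl in compound 4.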